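This account rests on a few compounds, and the source may have more. Where it says the series, first, only, none or still open, it means among the compounds named here.

Measured in a functional assay on HL-60 cells (Homo sapiens) for antiproliferative activity, read by MTT assay, with a stated time of 72 h; a lower number here means a stronger inhibitor, a higher number a weaker inhibitor:
- Compound 1 `CCOc1ccc(-c2ncnn2-c2cc(OC)c(OC)c(OC)c2)cc1Cl`: 3 nM
- Compound 2 `COc1cc(-n2ncnc2-c2ccc(OC(F)(F)F)cc2)cc(OC)c1OC`: > 10000 nM (a limit, not a number)

Among the compounds with values here, compound 2 stands at a limit of this assay, with > 10000 nM as its only reading. No number is therefore available for it, and any step away from it is only approximate.

Compound 3 `CCOc1ccc(-c2ncnn2-c2cc(OC)c(OC)c(OC)c2)cc1` is the next entry, and it changes the trifluoromethoxy of compound 2 to ethoxy: ethyl in place of trifluoromethyl on an oxygen on an aromatic ring.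

Within the data shown here, no measured pair differs in one place only, so no measured step sets the size of this one. The expectation rests on compound 1, which also carries ethoxy and gives 3 nM. The expected step is an at least 660-fold lower number from compound 2 to compound 3 (2.82 log units; beyond the scatter), towards stronger inhibition in this assay and well beyond the scatter. For compound 3 the estimated value is 15 nM, with an expected range of 2 nM to 150 nM.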

Compound 3, half-maximal inhibitory concentration: 20 nM
Compound 3: middle estimate off by 1.3-fold (0.12 log units), on the low side; the measured number falls inside the stated range.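

In this assay, ethyl in place of trifluoromethyl on an oxygen on an aromatic ring gives an at least 500-fold lower number from compound 2 to compound 3 (2.69 log units; beyond the scatter), so this single change separates a strong inhibitor from a compound without a numerical reading. The size of that step is a bound and not a measurement, since compound 2 stands at a limit: the limit of > 10000 nM in this assay, at which 1 of the 3 values shown sits.

Hydrogen in place of chloro on an aromatic carbon gives a 6.7-fold higher number from compound 1 to compound 3 (0.82 log units; beyond the scatter), so the chloro adds to the activity of the ethoxy series, but compound 3 remains a strong inhibitor without it.

Going by these compounds, how far activity tracks the group on this oxygen remains open: a methoxy or a longer chain such as propoxy would place further points between ethoxy and trifluoromethoxy. A fluorine or an amine in place of the chloro would show how specific that gain is.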